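Replacing the selenium-bearing chain of compound 1 with aminoethoxy

A few compounds are considered here, and "the series" means these few. Any claim that something is new, unique, unknown or untested is made for them only; others in the source may bear on it.

compound 1 `COc1ccc(N(C)c2nc(C)nc3ccccc23)cc1C(=O)OCCC[Se]C#N`: 250 nM
compound 2 `Cc1nc(N(C)c2ccc([Se]C#N)c(Cl)c2)c2ccccc2n1`: 7 nM

Of the compounds shown here, two have been measured in a functional assay on A549 cells (Homo sapiens) for inhibition, read by MTT assay, with a stated time of 48 h; on this read-out higher numbers stand for weaker inhibition and lower numbers for stronger inhibition. Compound 1 gives 250 nM in this assay, and compound 2 gives 7 nM. Compound 1 thus stands with the highest of the two numbers, and its gap to compound 2 is beyond the usual scatter of repeated measurements, so compound 2 is the stronger inhibitor of the pair.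

Compound 3 `COc1ccc(N(C)c2nc(C)nc3ccccc23)cc1OCCN` has not yet been measured. It differs from compound 1 by a group of 4 heavy atoms (2 carbon, 1 nitrogen, 1 oxygen; no ring) in place of a group of 9 heavy atoms (5 carbon, 1 nitrogen, 2 oxygen, 1 selenium; no ring), on an aromatic carbon. Within the data shown here, no pair of measured compounds differs in only one place, so there is no measured step to lean on for this change. What can be said is that both measured compounds carry selenium, whereas compound 3 carries none, and the number for compound 1 is already the weaker of the two that exist.

For compound 3 the expected step in this assay is a 6.0-fold higher number from compound 1 to compound 3 (0.78 log units; beyond the scatter), in the direction of weaker inhibition. The estimate for compound 3 in this assay is 1500 nM, with a range from 300 nM to 8000 nM.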

Compound 3, half-maximal inhibitory concentration: 122 nM
Beside the measured number, compound 3's estimate is 12-fold (1.09 log units) above it; the measured number lies below the stated range.
By their numbers in this assay, from the lowest: compound 2; then compound 3; then compound 1.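

In this assay, exchanging the selenium-bearing group of 9 heavy atoms for 2-aminoethoxy, on the aromatic carbon ortho to a methoxy group, gives a 2.0-fold lower number from compound 1 to compound 3 (0.31 log units; beyond the scatter), a modest step beyond the scatter towards stronger inhibition. The earlier compounds shown here could not show this, as both carry selenium: on the core of compound 1, this position accepts a smaller, selenium-free group with no loss of inhibition, so the selenium-bearing chain is not needed at this position for the activity seen in this pair. Nothing measured here accounts for the size or direction of the step.

The step replaces the whole group at once, so it cannot separate the part played by the selenium, the carbonyl, the chain length or the terminal amine of 2-aminoethoxy. As far as these compounds go, it also remains open how far the position would follow this trend with a longer chain such as 3-aminopropoxy, with 2-hydroxyethoxy, where a hydroxyl takes the place of the amine, or with a carboxylic acid.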